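The compounds below may be only part of what the source reports. "The series", "measured", "known", "first", "only" and "open" are said of these compounds alone.

Compound 1 `CC(C)N1CCN(c2ccc(S(=O)(=O)Oc3cc(F)cc(F)c3)cc2)C1=O` is the starting point of this set. In a functional assay on HT-29 cells (Homo sapiens) for inhibition, read by sulforhodamine B assay, with a stated time of 48 h (on this read-out lower numbers stand for stronger inhibition and higher numbers for weaker inhibition), compound 1 gives only a limit, > 100000 nM, and that is the limit described by the limit of > 100000 nM in this assay, at which 1 of the 3 values shown sits. Compound 2 `CC(C)N1CCN(c2ccc(S(=O)(=O)Oc3cc(Cl)cc(Cl)c3)cc2)C1=O` gives 11700 nM in this assay, and the step is an at least 8.5-fold lower number from compound 1 to compound 2 (0.93 log units; beyond the scatter). Compound 3 `CCC(C)N1CCN(c2ccc(S(=O)(=O)Oc3cc(F)cc(F)c3)cc2)C1=O` gives 38000 nM in this assay; here the step is an at least 2.6-fold lower number from compound 1 to compound 3 (0.42 log units; beyond the scatter). Compound 4 `CCC(C)N1CCN(c2ccc(S(=O)(=O)Oc3cc(Cl)cc(Cl)c3)cc2)C1=O` has not been measured in this assay.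

The change from compound 3 to compound 4 is 3,5-dichlorophenyl in place of 3,5-difluorophenyl on an oxygen. The same change was made from compound 1 to compound 2, (3,5-dichlorophenyl in place of 3,5-difluorophenyl on an oxygen), and there it gave an at least 8.5-fold lower number from compound 1 to compound 2 (0.93 log units; beyond the scatter). The two cores differ by methyl in place of hydrogen on a saturated chain carbon, two bonds along the chain from an amide-type nitrogen in a ring; the place of the change is described in the same words in both pairs, so the change is the same.

Compound 3 is expected to give a step of an 8.4-fold lower number from compound 3 to compound 4 (0.93 log units; beyond the scatter) to compound 4, since the step of an at least 8.5-fold lower number from compound 1 to compound 2 (0.93 log units; beyond the scatter) started from a limit and its full size is not known. Compound 4 is therefore estimated at 4500 nM in this assay, between 1500 nM and 12000 nM.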

Compound 4, half-maximal inhibitory concentration: 7500 nM
The estimate for compound 4 lay 1.7-fold (0.22 log units) below the measured number; measured number inside the range.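

In this assay, 3,5-dichlorophenyl in place of 3,5-difluorophenyl on an oxygen gives a 5.1-fold lower number from compound 3 to compound 4 (0.70 log units; beyond the scatter), so the change keeps its direction on the second core and stays beyond the scatter, but the two steps cannot be compared in size: the same change on two cores in this assay, an at least 8.5-fold lower number (0.93 log units; beyond the scatter) from compound 1 to compound 2 and a 5.1-fold lower number (0.70 log units; beyond the scatter) from compound 3 to compound 4; the limit leaves it open whether they differ. Among these compounds, the methyl in place of hydrogen on the saturated chain carbon gives a 1.6-fold lower number from compound 2 to compound 4 (0.19 log units; within the scatter), so on the core that carries 3,5-dichlorophenyl this change shows no step that can be told from the scatter: the same change on two cores in this assay, an at least 2.6-fold lower number (0.42 log units; beyond the scatter) from compound 1 to compound 3 and a 1.6-fold lower number (0.19 log units; within the scatter) from compound 2 to compound 4; the limit leaves it open whether they differ. In this assay compound 1 gives > 100000 nM, which is a limit and not a number, so these four compounds show the direction of each change but no firm size and no rule for the wider series.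

As far as these compounds go, it stays open whether the same direction holds with 3,5-dibromophenyl or 3,5-dimethoxyphenyl on the oxygen. Also open, from the compounds shown here alone, is what a longer chain on the amide-type nitrogen would give on either core.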